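This account rests on a few compounds, and the source may have more. Where it says the series, first, only, none or still open, it means among the compounds named here.

Working notes on the series. Compound 1, `O=S(=O)(Nc1nccs1)c1ccc2c(c1)OCC[C@@H]2c1ccc(C(F)(F)F)cc1N1CCNCC1`, is the more polar of the two measured compounds in a physicochemical assay for lipophilicity (a higher number here means a more lipophilic compound, a lower number a more polar compound), where compound 1 gives 1.4. Compound 2, `O=S(=O)(Nc1ncccn1)c1ccc2c(c1)OCC[C@@H]2c1ccc(C(F)(F)F)cc1-c1ccc(F)nc1`, gives 2.8 in this assay, a number that sits well beyond the scatter above the value of compound 1. For the measured compounds named here, no step between compounds that differ in a single place has been measured, so the pair can only be read as two separate values.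

Compound 3, `Cn1nccc1-c1cc(C(F)(F)F)ccc1[C@H]1CCOc2cc(S(=O)(=O)Nc3nccs3)ccc21`, is not yet measured in this assay. It differs from compound 1 in one place: 1-methyl-1H-pyrazol-5-yl in place of piperazin-1-yl on an aromatic carbon. A ring that carries a hydrogen-bond donor leaves and an aromatic ring with none enters, while the count of hydrogen-bond acceptors stays the same.

The step from compound 1 to compound 3 is expected to be a number 1.60 log units higher from compound 1 to compound 3 (beyond the scatter), upward and clearly beyond the scatter. Compound 3 is estimated at 3 in this assay, with a range from 2.4 to 3.6.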

Compound 3, distribution coefficient: 2.2
The estimate for compound 3 lay 0.80 log units above the measured number, and the stated range ends above it.
By their numbers in this assay, from the lowest: compound 1; then compound 3; then compound 2.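

Working notes, continued. For the compounds shown here, on an aromatic carbon ortho to a large group and meta to a trifluoromethyl group, 1-methyl-1H-pyrazol-5-yl in place of piperazin-1-yl gives, in this assay, a number 0.80 log units higher from compound 1 to compound 3 (beyond the scatter), the first reading of a change in one place. The two groups match in heavy atoms and hydrogen-bond acceptors, so the step accompanies the exchange of a six-membered non-aromatic ring carrying a hydrogen-bond donor for a five-membered aromatic ring with none, and this single pair cannot separate those two differences. Nothing at hand accounts for the step.

The compounds shown leave open how a morpholine or an N-methylpiperazine would read at this position in this assay. They also leave open whether the same exchange gives a step of similar size on any core other than that of compound 1.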